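Short hydroxy-chain amides against horse liver alcohol dehydrogenase

The compounds below may be only part of what the source reports. "The series", "measured", "known", "first", "only" and "open" are said of these compounds alone.

Measured so far in an assay for inhibition of alcohol dehydrogenase (Equus caballus); on this read-out higher numbers stand for weaker inhibition and lower numbers for stronger inhibition:
compound 1 `COCC(N)=O` gives 600000 nM
compound 2 `NC(=O)CCCCO` gives 4400000 nM
compound 3 `NC(=O)CCO` gives 8500000 nM

Compound 3 carries the highest number of the three. Among the compounds with values here, its nearest neighbour is compound 2, whose value is within the scatter of compound 3; the only value set apart from compound 3 beyond the scatter is that of compound 1.

The next compound is compound 4 `NC(=O)CCCO`. Its change from compound 3 is hydroxymethyl in place of hydroxy on a saturated chain carbon, two bonds along the chain from a carbonyl carbon.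

Within the data shown here, only one step among the measured compounds is defined, a 14-fold higher number from compound 1 to compound 3 (1.15 log units; beyond the scatter), and it concerns a different exchange, so it gives no direct guide here. Compound 2 and compound 3, which differ in chain length, show values within the scatter of each other. Lengthening by one carbon, as in compound 4, is therefore expected to leave this assay essentially unchanged, with the number for compound 4 expected to lie close to that of compound 3 and that of compound 2, perhaps marginally lower. The expected step is a 1.4-fold lower number from compound 3 to compound 4 (0.15 log units; within the scatter). Compound 4 is thus estimated at 6000000 nM, with a range from 2500000 nM to 15000000 nM.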

Compound 4, inhibition constant: 6800000 nM
Compound 4: middle estimate off by 1.1-fold (0.05 log units), on the low side, within the range that was stated.
By their numbers in this assay, from the lowest: compound 1; then compounds 2, 4 and 3 (each within the scatter of the next).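

In this assay, hydroxymethyl in place of hydroxy on a saturated chain carbon, two bonds along the chain from a carbonyl carbon, gives a 1.3-fold lower number from compound 3 to compound 4 (0.10 log units; within the scatter) and so leaves this position without a step beyond the scatter. The reverse exchange, hydroxy in place of hydroxymethyl on a saturated chain carbon, three bonds along the chain from a carbonyl carbon, gives a 1.5-fold higher number from compound 2 to compound 4 (0.19 log units; within the scatter), so the values of compound 2, compound 3 and compound 4 are not separated by chain length in this assay. No measurement bears on the reason for this result.

Still open, from the compounds shown here alone, is whether a longer chain than that of compound 2 stays within the scatter of these values. Going by these compounds, it is also open whether an amine or a carboxylic acid in place of the hydroxy changes the number in this assay.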